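Methyl to Benzyl at an Aromatic Nitrogen

The source may hold more compounds than are shown below. What is called first, only, known or untested is meant among the compounds shown, and "the series" means these compounds.

Compound 3 `Cn1c(SCC(=O)Nn2c(COc3ccc(Cl)cc3Cl)nc3ccccc3c2=O)nc(-c2ccc(O)cc2)c(C#N)c1=O` gives the highest of the three numbers in a functional assay on the whole organism (strain albino) for inhibition, with Rattus norvegicus as the target, read by paw edema, with stated times of 1 h and 3 h, at a dose of 100 mg/kg by the oral route (on this read-out higher numbers stand for a stronger effect at the one dose given and lower numbers for a weaker effect), namely 86%. Compound 1 `N#Cc1c(-c2ccc(O)cc2)nc(SCC(=O)Nn2c(COc3ccc(Cl)cc3Cl)nc3ccccc3c2=O)[nH]c1=O` gives 68.4% in this assay. Within the data shown here, the one single-change step, a number 17.6 percentage points higher from compound 1 to compound 3 (beyond the scatter), lies beyond the scatter. Compound 4 `N#Cc1c(-c2ccc(O)cc2)nc(SCC(=O)Nn2c(COc3ccc(Cl)cc3Cl)nc3ccccc3c2=O)n(Cc2ccccc2)c1=O` differs from compound 3 by phenyl in place of hydrogen on a saturated chain carbon bound to an aromatic nitrogen. Among the measured compounds shown here, no measured step covers this change directly. Compound 2 `N#Cc1c(-c2ccccc2)nc(SCC(=O)Nn2c(COc3ccc(Cl)cc3Cl)nc3ccccc3c2=O)n(Cc2ccccc2)c1=O`, which carries a benzyl on its aromatic nitrogen and a phenyl without the hydroxyl, gives 79% in this assay, within the scatter of compound 3, so only a small shift is expected. Compound 4 is therefore expected to give 82% in this assay, within 70% to 92%. The expected step is a number 4 percentage points lower from compound 3 to compound 4 (within the scatter), not beyond the scatter.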

Compound 4, a percentage reported as inhibition, in the whole organism at one dose (the size of the read-out at that dose, not a potency): 61.4%
The estimate for compound 4 lay 20.6 percentage points above the measured number, and the stated range ends above it.
By their numbers in this assay, from the lowest: compounds 4 and 1 (each within the scatter of the next); then compounds 2 and 3 (each within the scatter of the next).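

In this assay the gain that methyl brought on the aromatic nitrogen does not carry over to benzyl (a number 24.6 percentage points lower from compound 3 to compound 4 (beyond the scatter)), and benzyl in place of hydrogen there gives no step beyond the scatter (a number 7 percentage points lower from compound 1 to compound 4 (within the scatter)). With benzyl present, hydroxy in place of hydrogen on an aromatic carbon also goes with a lower number (a number 17.6 percentage points lower from compound 2 to compound 4 (beyond the scatter)). No evidence on the cause of these steps is at hand. On these data alone, whether an ethyl or a longer chain on that nitrogen stays close to methyl or falls toward benzyl remains open, as does the effect of a methoxy in place of the hydroxy.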